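Solubility notes: amide substituent change on the hydroxymethyl core

The compounds below may be only part of what the source reports. "The series", "measured", "known", "first", "only" and "open" are said of these compounds alone.

Three compounds have a reading in a physicochemical assay for solubility; a lower number here means a less soluble compound, a higher number a more soluble compound. Compound 1 `CNC(=O)c1cc(C(=O)NC2CC2)cc2c1O[C@H](CF)[C@H]2c1ccccc1` gives 8 ug/mL. For compound 2 `CC[C@@]1(c2ccccc2)COc2c(C(=O)NC)cc(C(=O)N[C@H]3[C@@H]4COC[C@@H]43)cc21` the result is a limit of the assay, >= 152 ug/mL. For compound 3 `CNC(=O)c1cc(C(=O)N[C@H]2[C@@H]3COC[C@@H]32)cc2c1OC[C@@]2(CO)c1ccccc1` the result is likewise a limit, >= 202 ug/mL. For the measured compounds named here, the one step measured within the set, a step that the two limits leave unreadable from compound 2 to compound 3, cannot be sized because both ends sit at a limit; the limit of >= 152 ug/mL in this assay, at which 1 of the 3 values shown sits, and the limit of >= 202 ug/mL in this assay, at which 1 of the 3 values shown sits, mark where those two values rest. Compound 3 therefore stands at the upper edge of what this set has recorded, with no number of its own.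

Compound 4 `CNC(=O)c1cc(C(=O)N[C@H]2C[C@@H]2C)cc2c1OC[C@@]2(CO)c1ccccc1` differs from compound 3 by a group of 4 heavy atoms (4 carbon; one three-membered non-aromatic ring of carbon only) in place of a group of 6 heavy atoms (5 carbon, 1 oxygen; one three-membered non-aromatic ring of carbon only, one five-membered non-aromatic ring with 1 hetero atom), on an amide-type nitrogen. Going by the values given here, no measured step covers a change of this kind, so the only guide is the general level of the set: compound 1, which carries a different amide group and a different core, sits far below the two limits, while the hydroxymethyl core of compound 3 is retained in compound 4. The step of an at least 3.3-fold lower number from compound 3 to compound 4 (0.52 log units; beyond the scatter) is expected to be a loss, though of uncertain size. Compound 4 is estimated at 60 ug/mL, with a range from 15 ug/mL to 200 ug/mL.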

Compound 4, solubility: >= 229 ug/mL
Compound 4 gave a limit, no number (the forecaster's own chance of this, stated with the estimate: 20%); at least 3.8-fold (0.58 log units) between middle value and limit.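

In this assay, compound 3 and compound 4 both rest at limits, so the step between them cannot be read. The compounds shown leave open whether 2-methylcyclopropyl on the amide-type nitrogen changes the reading in this assay relative to the group it replaces.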